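Sulfonyl aryl swap on the shared benzoxazole-free core, next step

The source may report more compounds than this note shows. Statements on the series, on what has been measured and on what is new or still open speak of the compounds shown alone.

Among the compounds with values here, two measured members define the series so far. Compound 1 `Cc1ccccc1S(=O)(=O)Nc1ccc2oc(-c3ccccc3)nc2c1` gives in an assay on cells for inhibition of HSP60/HSP10 (Homo sapiens), with a stated time of 60 min (on this read-out higher numbers stand for weaker inhibition and lower numbers for stronger inhibition), a value of > 100000 nM, which is a limit of the assay and not a number. Within the data shown here, compound 2 `O=S(=O)(Nc1ccc2oc(-c3ccccc3)nc2c1)c1cccs1` gives in this assay 90000 nM, the only real number obtained. The one other result recorded, that of compound 1, is a limit, in line with the limit of > 100000 nM in this assay, at which 1 of the 2 values shown sits. Among the measured compounds shown here, the single step between them, an at least 1.1-fold lower number from compound 1 to compound 2 (0.04 log units; that floor lies within the scatter), is a floor within the scatter and shows no real difference between the two sulfonyl aryl groups.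

Compound 3 `COc1ccc(Cl)cc1S(=O)(=O)Nc1ccc2oc(-c3ccccc3)nc2c1` is not yet measured. It differs from compound 2 by 5-chloro-2-methoxyphenyl in place of thiophen-2-yl on a sulfonyl sulfur. For the measured compounds named here, the only measured step that bears on it is the one from compound 1 to compound 2, which lies within the scatter, and compound 1, which also carries a six-membered carbon-only ring on the sulfonyl sulfur, reached only the assay limit. No step beyond the scatter is therefore expected in this assay, and a return to the limit is plausible. For compound 3 the expected value is 100000 nM (range 40000 nM to 250000 nM). The expected step of a 1.1-fold higher number from compound 2 to compound 3 (0.05 log units; within the scatter) from compound 2 to compound 3 is an estimate only.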

Compound 3, half-maximal inhibitory concentration: > 100000 nM
Compound 3 ended at the assay's limit; the forecaster's own chance of this, stated with the estimate: 50%; the middle value lies on the limit itself.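

Replacing thiophen-2-yl with 5-chloro-2-methoxyphenyl on the sulfonyl sulfur gives in this assay an at least 1.1-fold higher number from compound 2 to compound 3 (0.04 log units; that floor lies within the scatter), so this change shows no readable difference, although the entering group is larger and carries two substituents on a six-membered aromatic ring of carbon only. The steps between compound 1 and compound 3 cannot be read, as both results are limits of the assay and not numbers. This position has now held three aryl groups, and a second group with a six-membered ring of carbon only has failed to give a number, leaving compound 2 as the only member with a real value, and most of the series now sits at one end of the measurable range: the limit of > 100000 nM in this assay, at which 2 of the 3 values shown sit.

From the compounds shown here alone, how far compound 1 and compound 3 lie past the limit stays open, so the three sulfonyl aryl groups cannot be ranked. Also open, going by these compounds, is whether an amine or a carboxylic acid on the sulfonyl aryl ring, or a longer alkyl chain in its place on the sulfonyl sulfur, would give a clear step from compound 2.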